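Swapping Chloro for Amino on a Purine-like Scaffold

A few compounds are considered here, and "the series" means these few. Any claim that something is new, unique, unknown or untested is made for them only; others in the source may bear on it.

Measured compounds in a functional assay on ACHN cells (Homo sapiens) for cytotoxicity, read by sulforhodamine B assay, with a stated time of 48 h; on this read-out lower numbers stand for higher toxicity in this test and higher numbers for lower toxicity in this test:
Compound 1, `Nc1nc(Cl)c2ncn(Cc3ccc(CCl)cc3)c2n1`: 64600 nM
Compound 2, `ClCc1cccc(Cn2cnc3c(Cl)nc(Cl)nc32)c1`: 7240 nM
Compound 3, `ClCc1ccc(Cn2cnc3c(Cl)nc(Cl)nc32)cc1`: 14800 nM

Compound 2 gives the lowest number of the three, so it is the most toxic here. The difference between the core of compound 2 and the core of compound 3 is not broken down here. Going from compound 3 to compound 1 makes the change (amino in place of chloro on an aromatic carbon), and this step is a 4.4-fold higher number from compound 3 to compound 1 (0.64 log units; beyond the scatter). Compound 4, `Nc1nc(Cl)c2ncn(Cc3cccc(CCl)c3)c2n1`, is not yet measured; it arises from compound 2 by the same change, (amino in place of chloro on an aromatic carbon). Within the data shown here, because the step of a 4.4-fold higher number from compound 3 to compound 1 (0.64 log units; beyond the scatter) is the only guide, a step of similar size is expected from compound 2 to compound 4, namely a 4.4-fold higher number from compound 2 to compound 4 (0.65 log units; beyond the scatter). Compound 4 is therefore estimated at 32000 nM, roughly between 12000 nM and 85000 nM.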

Compound 4, concentration lethal to 50% of the cells: 29500 nM
Compound 4: middle estimate off by 1.1-fold (0.04 log units), on the high side, and the stated range covers the measured number.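

In this assay, amino in place of chloro gives a 4.1-fold higher number from compound 2 to compound 4 (0.61 log units; beyond the scatter) and so lower toxicity in this test on this core too. The size of the step carries over from one core to the other, and the two steps cannot be told apart: the same change on two cores in this assay, a 4.4-fold higher number (0.64 log units; beyond the scatter) from compound 3 to compound 1 and a 4.1-fold higher number (0.61 log units; beyond the scatter) from compound 2 to compound 4, 1.1-fold (0.03 log units) apart, within the scatter of two such steps. Among these compounds, this rests on only two pairs of compounds, so it does not show that the step would hold on a more different core, and it does not explain why the change has this effect.

As far as these compounds go, whether a larger amine or a methoxy group in the same place would give a similar step remains open. So does whether the step would hold in any other test.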